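Inverting one stereocentre in an aryl urea

The source may report more compounds than this note shows. Statements on the series, on what has been measured and on what is new or still open speak of the compounds shown alone.

Measured compounds:
- compound 1, `C[C@H](NC(=O)Nc1ccccc1Cl)c1ccccc1`: 106%
- compound 2, `C[C@@H](NC(=O)Nc1ccccc1I)c1ccccc1`: 96%

In an ADME assay on the whole organism with Oryza sativa as the target, tested at 10 uM (a lower number here means a stronger effect, a higher number a weaker effect of the compound at the concentration tested), compound 1 gives 106%. In this assay, for the measured compounds named here, compound 2 gives 96%, which is the lowest of the two numbers so far, but its nearest neighbour, compound 1, lies within the usual scatter of it, so the two read-outs cannot be told apart.

Compound 3, `C[C@H](NC(=O)Nc1ccccc1I)c1ccccc1`, has not yet been measured. Compared with compound 2, the change is the two compounds have the same atoms and bonds and differ only in configuration as drawn: 1 of 1 stereo elements differ; a stereocentre at a saturated chain carbon is drawn R in compound 2 and S in compound 3. Going by the values given here, no step between two measured compounds of this kind is available, so there is no direct guide for the size of the effect. With both measured values sitting close to one another, the expectation for compound 3 is a read-out near the two measured numbers, and the step from compound 2 to compound 3 is estimated to be a number 4 percentage points higher from compound 2 to compound 3 (within the scatter), not beyond the scatter in either direction. Compound 3 is therefore expected to give about 100% in this assay, with a likely range from 85% to 115%.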

Compound 3, a percentage reported as activity, at one concentration (the size of the read-out at that concentration, not a potency): 98%
Compound 3: middle estimate off by 2 percentage points, on the high side; the measured number falls inside the stated range.
By their numbers in this assay, from the lowest: compounds 2, 3 and 1 (each within the scatter of the next).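

In this assay, the stereocentre at the saturated chain carbon now has a measured step of its own. Going from R to S gives a number 2 percentage points higher from compound 2 to compound 3 (within the scatter), so with iodo on the aromatic carbon the configuration as drawn makes no difference that can be read at this concentration, and this reading concerns configuration alone: the fact that compounds 2 and 3 differ only in the configuration as drawn. For the compounds shown here, the new compound also gives the first comparison of the two halogens with the stereocentre drawn the same way, where iodo in place of chloro gives a number 8 percentage points lower from compound 1 to compound 3 (within the scatter), so this change cannot be read as an effect either.

The compounds shown leave open whether the stereocentre would count with a different group on the aromatic carbon, such as an amine or a carboxylic acid. Going by these compounds alone, they also leave open whether a longer chain at the stereocentre would shift the read-out in this assay beyond the scatter, since all the steps so far stay within it.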